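A Third Methoxy Group and Its Effect on Cytotoxicity

The source may report more compounds than this note shows. Statements on the series, on what has been measured and on what is new or still open speak of the compounds shown alone.

Measured in a functional assay on M14 cells (Homo sapiens) for cytotoxicity, read by sulforhodamine B assay, with a stated time of 48 h, tested at 100 uM; a higher number here means a weaker effect of the compound at the concentration tested, a lower number a stronger effect:

Compound 1, `COc1cc(-c2cc(/C=C/C(=O)c3ccc(N)cc3)[nH]n2)cc(OC)c1OC`: -78%
Compound 2, `COc1ccc(C(=O)/C=C/c2cc(-c3cc(OC)c(OC)c(OC)c3)n[nH]2)cc1OC`: -68%
Compound 3, `COc1ccc(-c2cc(/C=C/C(=O)c3ccc(N)cc3)[nH]n2)cc1OC`: -90%

Compound 3 and compound 1 share a core and differ in one place: methoxy in place of hydrogen on an aromatic carbon. This change made a number 12 percentage points higher from compound 3 to compound 1 (beyond the scatter). Compound 2 has a core unlike that of compound 3, and the difference between the two cores is not broken down here. Between compound 1 and compound 2 the change is a number 10 percentage points higher from compound 1 to compound 2 (within the scatter), so these two cannot be set in order of strength against each other.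

Compound 4, `COc1cc(C(=O)/C=C/c2cc(-c3cc(OC)c(OC)c(OC)c3)n[nH]2)cc(OC)c1OC`, has not yet been measured in this assay. It arises from compound 2 by methoxy in place of hydrogen on an aromatic carbon, the same change that turns compound 3 into compound 1, made at the same kind of place. On that one earlier instance, the step from compound 2 to compound 4 is expected to be a number 10 percentage points higher from compound 2 to compound 4 (within the scatter), about the size of a number 12 percentage points higher from compound 3 to compound 1 (beyond the scatter), with wide uncertainty since it rests on a single pair. Compound 4 is therefore estimated to give -58% in this assay, most likely between -80% and -36%.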

Compound 4, a percentage reported as activity, at one concentration (the size of the read-out at that concentration, not a potency): -88%
Compound 4: the middle estimate sits 30 percentage points above what was measured; the whole stated range lies above it.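

In this assay the added methoxy group gave a number 20 percentage points lower from compound 2 to compound 4 (beyond the scatter) and thus a stronger effect, whereas the same replacement of hydrogen by methoxy gave a number 12 percentage points higher from compound 3 to compound 1 (beyond the scatter) and thus a weaker effect. Set side by side, the two instances clearly disagree: the same change on two cores in this assay, a number 12 percentage points higher (beyond the scatter) from compound 3 to compound 1 and a number 20 percentage points lower (beyond the scatter) from compound 2 to compound 4, 32 percentage points apart, beyond the scatter of two such steps. Within the data shown here, this shows that, in this series, the result of adding a methoxy group on one core cannot simply be carried over to another core, but with only two pairs it gives no reason for the disagreement and no rule for predicting the result on any further core.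

The compounds shown leave open whether a hydroxy group or a longer ethoxy chain in place of this methoxy group would also give opposite results on the two cores. They also leave open how these compounds would compare across a range of concentrations, since each reading comes from one concentration and is not a potency.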